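The source may report more compounds than this note shows. Statements on the series, on what has been measured and on what is new or still open speak of the compounds shown alone.

In a functional assay on PC-3 cells (Homo sapiens) for cytotoxicity (on this read-out lower numbers stand for an effect already at smaller amounts and higher numbers for an effect only at larger amounts of compound), the result for compound 1 `COC1=C(C)C(=O)/C(=C(O)/C=C/c2ccc(O)cc2)C(=O)C1(C)C` is only a limit, > 20 ug/mL. Compound 2 `COC1=C(C)C(=O)/C(=C(O)/C=C/c2ccc(C)cc2)C(=O)C1(C)C` gives 8.2 ug/mL. Compound 3 `COC1=C(C)C(=O)/C(=C(O)/C=C/c2c(C)cccc2C)C(=O)C1(C)C` gives 17.1 ug/mL, the higher of the two actual numbers. Compound 4 `C=Cc1ccccc1/C=C/C(O)=C1/C(=O)C(C)=C(OC)C(C)(C)C1=O` differs from it by one swap: 2-vinylphenyl in place of 2,6-dimethylphenyl on a double-bonded chain carbon bound to a double-bonded chain carbon. The closest guides are the other changes on this aromatic ring. Replacing 4-methylphenyl with 2,6-dimethylphenyl gave a 2.1-fold higher number from compound 2 to compound 3 (0.32 log units; beyond the scatter), a modest step, and replacing hydroxy with methyl gave an at least 2.4-fold lower number from compound 1 to compound 2 (0.38 log units; beyond the scatter). Since these steps are small, the new swap is expected to stay within the scatter, with only a slight lean to a lower number. The expected change is a 1.4-fold lower number from compound 3 to compound 4 (0.15 log units; within the scatter). Compound 4 is estimated at 12 ug/mL, within a range of 5 ug/mL to 24 ug/mL.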

Compound 4, concentration for half-maximal effect: 4.6 ug/mL
Beside the measured number, compound 4's estimate is 2.6-fold (0.42 log units) above it, outside the stated range (below it).
By their numbers in this assay, from the lowest: compounds 4 and 2 (each within the scatter of the next); then compound 3. At a limit, above all of these: compound 1.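

In this assay, the step of a 3.7-fold lower number from compound 3 to compound 4 (0.57 log units; beyond the scatter) shows that two aromatic groups of equal heavy-atom count, 2-vinylphenyl and 2,6-dimethylphenyl, can differ beyond the scatter at this place on the chain. The step of a 1.8-fold lower number from compound 2 to compound 4 (0.25 log units; within the scatter) leaves 2-vinylphenyl and 4-methylphenyl indistinguishable here. The step of an at least 4.3-fold lower number from compound 1 to compound 4 (0.63 log units; beyond the scatter) is only a minimum and rests on a limit: the limit of > 20 ug/mL in this assay, at which 1 of the 4 values shown sits.

As far as these compounds go, whether the vinyl group itself matters stays open. So does how a 2-ethylphenyl or 2-aminophenyl group would compare in the same place.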